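This account rests on a few compounds, and the source may have more. Where it says the series, first, only, none or still open, it means among the compounds named here.

Measured in a functional assay on NCI-H1581 cells (Homo sapiens) for antiproliferative activity, read by CCK-8 assay, with a stated time of 72 h; on this read-out lower numbers stand for stronger inhibition and higher numbers for weaker inhibition:
Compound 1 `COc1cc(OC)c(Cl)c(-c2ccc3c(NC(=O)c4ccc(C5CCN(C)CC5)cc4)n[nH]c3n2)c1Cl`: 8.2 nM
Compound 2 `CCN1CCN(c2ccc(C(=O)Nc3n[nH]c4nc(-c5c(Cl)c(OC)cc(OC)c5Cl)ccc34)cc2)CC1`: 0.7 nM
Compound 3 `COc1cc(OC)c(Cl)c(-c2ccc3c(NC(=O)c4ccc(N5CCN(C(C)C)CC5)cc4)n[nH]c3n2)c1Cl`: 1.4 nM

The standing of compound 3 rests on two steps. The data show a 2.0-fold higher number from compound 2 to compound 3 (0.30 log units; within the scatter). They also show a 5.9-fold lower number from compound 1 to compound 3 (0.77 log units; beyond the scatter), so its number sits with the closer of its two neighbours and clearly apart from the other.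

Compound 4 `COc1cc(OC)c(Cl)c(-c2ccc3c(NC(=O)c4ccc(N5CCN(C6CCC6)CC5)cc4)n[nH]c3n2)c1Cl` has not yet been measured. It carries cyclobutyl in place of isopropyl on an amine nitrogen in a ring.

For the measured compounds named here, the most relevant evidence is the one measured change at this same nitrogen, where the data give a 2.0-fold higher number from compound 2 to compound 3 (0.30 log units; within the scatter). That small change of the group on this nitrogen did not move the number beyond the scatter. The larger steps, a 12-fold lower number from compound 1 to compound 2 (1.07 log units; beyond the scatter) and a 5.9-fold lower number from compound 1 to compound 3 (0.77 log units; beyond the scatter), replace the whole 1-methylpiperidin-4-yl group, so they say little about an exchange confined to this nitrogen. No cyclic group on this nitrogen has been measured, which leaves the estimate somewhat open.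

The step expected in this assay is therefore none beyond the scatter, an estimated 1.1-fold higher number from compound 3 to compound 4 (0.03 log units; within the scatter). The estimate for compound 4 is 1.5 nM, with an expected range from 0.6 nM to 4 nM.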

Compound 4, half-maximal inhibitory concentration: 2.3 nM
For compound 4 the middle estimate is 1.5-fold (0.19 log units) below the measured one, within the range that was stated.
By their numbers in this assay, from the lowest: compounds 2, 3 and 4 (each within the scatter of the next, the first and the last beyond it); then compound 1.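

Cyclobutyl brings a ring onto the amine nitrogen of the piperazine for the first time, and in this assay the exchange for isopropyl gives a 1.6-fold higher number from compound 3 to compound 4 (0.22 log units; within the scatter), so a four-membered carbon ring at this place cannot be told apart from the branched chain. Set against the ethyl group, however, cyclobutyl gives a 3.3-fold higher number from compound 2 to compound 4 (0.52 log units; beyond the scatter), the first step confined to this nitrogen that passes beyond the scatter, even though neither of the two smaller steps linking ethyl, isopropyl and cyclobutyl does so. The 4-cyclobutylpiperazin-1-yl group also keeps an advantage over the 1-methylpiperidin-4-yl group, with a 3.6-fold lower number from compound 1 to compound 4 (0.55 log units; beyond the scatter), so this replacement remains clearly favourable in this cell read-out even with the ring on the nitrogen.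

As far as these compounds go, whether cyclopropyl, cyclopentyl or a 2-hydroxyethyl chain on this nitrogen would sit with ethyl, with cyclobutyl or further up remains open, and three substituents are too few to establish a trend with the size of the group. Nothing among the data available here accounts for any of these differences.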